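Methoxy on the phenyl of compound 3

The source may hold more compounds than are shown below. What is called first, only, known or untested is meant among the compounds shown, and "the series" means these compounds.

Among the compounds with values here, in a functional assay on HepG2 cells (Homo sapiens) for antiproliferative activity, read by MTT assay, with a stated time of 72 h (on this read-out higher numbers stand for weaker inhibition and lower numbers for stronger inhibition), compound 3 (`COc1ncc(-c2ccc3c(c2)N(c2ccccc2)C(=O)CO3)cc1NS(=O)(=O)c1ccc(F)cc1`) gives 14000 nM, the lowest number measured so far. Compound 2 (`COc1ncc(-c2ccc3c(c2)N(c2ccc(F)cc2)C(=O)CO3)cc1NS(=O)(=O)c1ccc(F)cc1`) gives 36400 nM. Compound 1 (`COc1cccc(N2C(=O)COc3ccc(-c4cnc(OC)c(NS(=O)(=O)c5ccc(F)cc5)c4)cc32)c1`) gives > 40000 nM, which is a limit of the assay. Compound 4 (`COc1ccc(N2C(=O)COc3ccc(-c4cnc(OC)c(NS(=O)(=O)c5ccc(F)cc5)c4)cc32)cc1`) carries methoxy in place of hydrogen on an aromatic carbon, para to a large group: methoxy in place of hydrogen on an aromatic carbon. Within the data shown here, two measured steps bear on this change. Hydrogen in place of fluoro gave a 2.6-fold lower number from compound 2 to compound 3 (0.41 log units; beyond the scatter), and hydrogen in place of methoxy gave an at least 2.8-fold lower number from compound 1 to compound 3 (0.45 log units; beyond the scatter). Both point the same way, so the reverse change is expected to give a modest rise in this assay. The expected step is a 2.1-fold higher number from compound 3 to compound 4 (0.33 log units; beyond the scatter). The estimate for compound 4 is 30000 nM, with an expected range of 14000 nM to 60000 nM.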

Compound 4, half-maximal inhibitory concentration: 13100 nM
Estimate against measurement, compound 4: 2.3-fold (0.36 log units) above, and the stated range ends above it.
By their numbers in this assay, from the lowest: compounds 4 and 3 (each within the scatter of the next); then compound 2. At a limit, above all of these: compound 1.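

In this assay, phenyl to 4-methoxyphenyl gives a 1.1-fold lower number from compound 3 to compound 4 (0.03 log units; within the scatter), so methoxy is tolerated on this carbon, whereas fluoro in compound 2 is not, with a 2.8-fold lower number from compound 2 to compound 4 (0.44 log units; beyond the scatter). Where the methoxy sits therefore counts, not only its presence: 4-methoxyphenyl in place of 3-methoxyphenyl gives an at least 3.0-fold lower number from compound 1 to compound 4 (0.48 log units; beyond the scatter). Compound 1 gives > 40000 nM, which is a limit of the assay, so that step is only a floor.

Open, from the compounds shown here alone, is whether an amine, a carboxylic acid or a chain longer than methoxy on this carbon would give a number clearly below those of compound 3 and compound 4, which lie within the scatter of each other.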